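A Sulfonamide Pair Where Two Chlorines Are Removed

This account rests on a few compounds, and the source may have more. Where it says the series, first, only, none or still open, it means among the compounds named here.

The series turns on a small set of aryl sulfonamides. For the measured compounds named here, compound 1 `O=C(c1ccccc1)c1cccc(NS(=O)(=O)c2ccc(Cl)cc2Cl)c1` is the only member of the set with a measured number: in an assay on CHO cells for binding affinity to integrin alpha-1 (Homo sapiens), read by WST assay, with a stated time of 2 h (on this read-out lower numbers stand for an effect already at smaller amounts and higher numbers for an effect only at larger amounts of compound), compound 1 gives 17000 nM, a weak result. Its two neighbours give even less. Compound 2 `CC(=O)c1cccc(NS(=O)(=O)c2ccc(Cl)cc2Cl)c1` is reported in this assay as "not active" (no number reported), and compound 3 `CN(c1cccc(C(=O)c2ccccc2)c1)S(=O)(=O)c1ccc(Cl)cc1Cl` is likewise reported in this assay as "not active" (no number reported). Compound 1 therefore stands at the top of what is shown, with no other number to compare it to. The untested compound 4 `O=C(c1ccccc1)c1cccc(NS(=O)(=O)c2ccccc2)c1` differs from compound 1 in a single place: phenyl in place of 2,4-dichlorophenyl on a sulfonyl sulfur. Going by the values given here, with no step between measured compounds available, the direction must be judged from the weak standing of compound 1 alone. The expected step in this assay from compound 1 to compound 4 is a 2.6-fold higher number from compound 1 to compound 4 (0.42 log units; beyond the scatter), a loss that may carry compound 4 toward the same inactive outcome as compound 2 and compound 3. Compound 4 is estimated in this assay at 45000 nM, within a range from 15000 nM to 150000 nM.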

Compound 4, half-maximal effective concentration: "not active" (no number reported)
Nothing numeric was reported for compound 4; no gap can be computed for the estimate.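

For the compounds shown here, compound 4 is reported as "not active" in this assay, and with no number for it, no step from compound 1 to compound 4 can be read. Nothing available here accounts for this result. The compounds shown leave open whether either chlorine of compound 1 alone sustains its measurable binding.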